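This account rests on a few compounds, and the source may have more. Where it says the series, first, only, none or still open, it means among the compounds named here.

In a physicochemical assay for solubility, in phosphate buffer, measured as kinetic solubility, with a stated time of 1 h, at pH 7.4 (a higher number here means a more soluble compound, a lower number a less soluble compound), compound 1 `COc1ccc2nc(C)cc(OCC(=O)Nc3cc(C)cc(C)c3)c2c1` gives 26000 nM, the lowest of the three numbers recorded so far. Compound 2 `Cc1cc(C)cc(NC(=O)COc2cc(C)nc3ccc(F)cc23)c1` gives 28000 nM, and compound 3 `Cc1cc(C)cc(NC(=O)COc2cc(C)nc3ccc(C)cc23)c1` gives 83000 nM. The step of a 1.1-fold higher number from compound 1 to compound 2 (0.03 log units; within the scatter) lies within the scatter, whereas a 3.2-fold higher number from compound 1 to compound 3 (0.50 log units; beyond the scatter) and a 3.0-fold higher number from compound 2 to compound 3 (0.47 log units; beyond the scatter) are modest changes beyond it. All three measured steps concern the substituent on an aromatic carbon of the shared core, while the amide-bearing part is the same in each compound.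

Compound 4 `COc1ccc2nc(C)cc(OCC(=O)Nc3nc(C)c(C)s3)c2c1` differs from compound 1 elsewhere: 4,5-dimethyl-1,3-thiazol-2-yl in place of 3,5-dimethylphenyl on an amide-type nitrogen. Among the measured compounds shown here, none of the measured steps alters this part of the molecule, so none of them bears on the change, and there is no precedent here for how this assay responds to it. The expectation must therefore be anchored on compound 1 alone, with a wide range to either side. Compound 4 is estimated at 28000 nM, with a range from 8000 nM to 100000 nM. The expected step is a 1.1-fold higher number from compound 1 to compound 4 (0.03 log units; within the scatter), with no direction beyond the scatter favoured.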

Compound 4, solubility: 31500 nM
Compound 4: the middle estimate sits 1.1-fold (0.05 log units) below what was measured; low and high end bracket the measured number.
By their numbers in this assay, from the lowest: compounds 1, 2 and 4 (each within the scatter of the next); then compound 3.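

In this assay, among the compounds shown here, 4,5-dimethyl-1,3-thiazol-2-yl in place of 3,5-dimethylphenyl on an amide-type nitrogen gives a 1.2-fold higher number from compound 1 to compound 4 (0.08 log units; within the scatter), the first reading for a part of the molecule that no earlier step touched. The one six-membered aromatic ring of carbon only gives way to one five-membered aromatic ring with 2 hetero atoms, and the numbers of the two compounds lie within the scatter of each other. No measurement shown here accounts for this result.

The compounds shown leave open whether the same holds with the methyl of compound 3 on the shared core, since the new group appears only with the methoxy of compound 1. They also leave open how a ring carrying an amine or a carboxylic acid, or a longer chain, would read on this nitrogen.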